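The source may hold more compounds than are shown below. What is called first, only, known or untested is meant among the compounds shown, and "the series" means these compounds.

For the measured compounds named here, in a functional assay on thoracic aorta (Rattus norvegicus, strain Wistar), with a stated time of 15 min (on this read-out lower numbers stand for an effect already at smaller amounts and higher numbers for an effect only at larger amounts of compound), compound 1 (`CC(NC(=O)NS(=O)(=O)c1ccc(Cl)cc1)c1cc(Br)ccc1OCc1ccccc1`) gives 57500 nM as the only number so far. Compound 2 (`COc1ccc(Br)cc1C(C)NC(=O)NS(=O)(=O)c1ccccc1`) gives > 300000 nM and this is a limit. Compound 3 (`CCOc1ccc(Br)cc1C(C)NC(=O)NS(=O)(=O)c1ccccc1`) gives > 300000 nM and this is also a limit. Compound 3 therefore stands at the limit of > 300000 nM in this assay, at which 2 of the 3 values shown sit, and no number can be read for it. Going by the values given here, the one measured step is a step that the two limits leave unreadable from compound 2 to compound 3 and offers no size to carry forward.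

Compound 4 (`CC(NC(=O)NS(=O)(=O)c1ccccc1)c1cc(Br)ccc1OCc1ccccc1`) follows from compound 3 by phenyl in place of methyl on a saturated chain carbon bound to an oxygen on an aromatic ring and the change reads ethoxy to benzyloxy. Among the compounds with values here, compound 4 shares benzyloxy with compound 1, and compound 1 at 57500 nM is the only guide, although the two also differ elsewhere. A move in this assay toward lower numbers is therefore expected, with its size poorly fixed. The expected step is an at least 3.0-fold lower number from compound 3 to compound 4 (0.47 log units; beyond the scatter) and it remains a loose expectation. For compound 4 the estimate is 100000 nM with an expected range from 40000 nM to 300000 nM and a reading of only a limit remains possible.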

Compound 4, half-maximal effective concentration: 130000 nM
Estimate against measurement, compound 4: 1.3-fold (0.11 log units) below, and the stated range covers the measured number.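

In this assay, phenyl in place of methyl on a saturated chain carbon bound to an oxygen on an aromatic ring gives an at least 2.3-fold lower number from compound 3 to compound 4 (0.36 log units; beyond the scatter), and phenyl in place of hydrogen at that place gives an at least 2.3-fold lower number from compound 2 to compound 4 (0.36 log units; beyond the scatter), so benzyloxy brings a readable number where methoxy and ethoxy give none. Hydrogen in place of chloro on an aromatic carbon gives a 2.3-fold higher number from compound 1 to compound 4 (0.35 log units; beyond the scatter), which shows that benzyloxy yields a number without the chloro group and that chloro adds a modest further step. The step between compound 2 and compound 3 cannot be read, and both remain limits: the limit of > 300000 nM in this assay, at which 2 of the 4 values shown sit.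

From the compounds shown here alone, whether the gain needs the phenyl ring or only a longer chain stays open, and an n-butoxy or a pyridylmethoxy group at this place would separate the two. Also open, going by these compounds, is whether the chloro step holds with methoxy or ethoxy in place of benzyloxy.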